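Swapping the benzyl arm for a methoxyethyl chain

This account rests on a few compounds, and the source may have more. Where it says the series, first, only, none or still open, it means among the compounds named here.

Among the measured compounds shown here, compound 2 `O/N=C(\Nc1ccc(F)c(Br)c1)c1nonc1NCc1ccccc1` is the reference point here: in an assay for inhibition of Indoleamine 2,3-dioxygenase 1 (Homo sapiens) (a higher number here means a weaker inhibitor, a lower number a stronger inhibitor), compound 2 gives 230 nM, the only plain number measured so far. Compound 1 `CN(C)c1nonc1/C(=N/O)Nc1ccc(F)c(Br)c1` differs only in the group on the nitrogen of the shared core. In this assay compound 1 gives > 5000 nM, which is a limit of the assay rather than a number. The resulting step of an at least 21-fold lower number from compound 1 to compound 2 (1.33 log units; beyond the scatter) rests on that limit, (the limit of > 5000 nM in this assay, at which 1 of the 2 values shown sits). Compound 3 `COCCNc1nonc1/C(=N/O)Nc1ccc(F)c(Br)c1` carries the change (methoxymethyl in place of phenyl on a saturated chain carbon bound to a nitrogen on an aromatic ring). For the measured compounds named here, no measured step tries this exact swap, but the step from compound 1 to compound 2 shows that the group on that nitrogen can move the number a great deal, and compound 3 again loses the phenyl. A weaker result is therefore expected for compound 3, estimated at 1500 nM, with a likely range from 400 nM to 6000 nM. That estimate means an expected 6.5-fold higher number from compound 2 to compound 3 (0.81 log units; beyond the scatter).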

Compound 3, half-maximal inhibitory concentration: 200 nM
Estimate against measurement, compound 3: 7.5-fold (0.88 log units) above, and the stated range ends above it.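

In this assay, putting methoxymethyl in place of phenyl on this chain gives a 1.2-fold lower number from compound 2 to compound 3 (0.06 log units; within the scatter), so a phenyl ring on this arm is not required for inhibition at this level: a chain with no ring serves as well. The dimethylamino group of compound 1 stays the odd one out, with an at least 25-fold lower number from compound 1 to compound 3 (1.39 log units; beyond the scatter). The true size of that step is unknown, since the value of compound 1 is a limit of the assay and not a number: the limit of > 5000 nM in this assay, at which 1 of the 3 values shown sits.

A plain propyl chain would show whether the oxygen of the 2-methoxyethyl chain plays any part. A methylamino group would help show whether the arm's length or the hydrogen kept on that nitrogen separates compound 1 from compound 2 and compound 3.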